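From Cyclohexyl to Methyl: An Expected Half-Life

The source may report more compounds than this note shows. Statements on the series, on what has been measured and on what is new or still open speak of the compounds shown alone.

Of the compounds shown here, three have been measured in an ADME assay on microsomes from liver (Homo sapiens) for metabolic stability; on this read-out lower numbers stand for a shorter-lived compound and higher numbers for a longer-lived compound. Compound 1 `CCc1nc2cc(Cl)ccn2c1C(=O)NCc1ccc2oc(C3CCCCC3)nc2c1` gives 0.17 h. Compound 2 `CCc1nc2ccc(Cl)cn2c1C(=O)NCc1ccc2oc(C3CCCCC3)nc2c1` gives 0.283 h, and compound 3 `CCc1nc2ccc(Cl)cn2c1C(=O)NCc1ccc2ccn(C)c2c1` gives 0.0933 h. Compound 1 sits between the other two, and its gaps to compound 2 and to compound 3 both fall within the usual scatter of this assay, so the three values read as one cluster of short-lived compounds. Compound 4 `CCc1nc2cc(Cl)ccn2c1C(=O)NCc1ccc2oc(C)nc2c1` differs from compound 1 by a single change: methyl in place of cyclohexyl on an aromatic carbon. Within the data shown here, no measured pair shows this change, so no step can be read off from the data. Compound 1 gives 0.17 h and the three measured values cluster closely, so compound 4 is expected to stay near them. The step of a 1.5-fold higher number from compound 1 to compound 4 (0.17 log units; within the scatter) is expected to remain within the scatter. Compound 4 is estimated at 0.25 h, with a range from 0.1 h to 0.6 h.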

Compound 4, half-life: > 2 h
Compound 4: a limit, no number; the forecaster's own chance of this, stated with the estimate: 5%; at least 8.0-fold (0.90 log units) between middle value and limit.
By their numbers in this assay, from the lowest: compounds 3, 1 and 2 (each within the scatter of the next, the first and the last beyond it). At a limit, above all of these: compound 4.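

At this aromatic carbon, next to the ring nitrogen and next to the ring oxygen, the group proves decisive in this assay: methyl in place of cyclohexyl gives an at least 11-fold higher number from compound 1 to compound 4 (1.07 log units; beyond the scatter). The > 2 h of compound 4 is a limit and not a number. The earlier compounds showed no such reach at this position, and the full size of the step cannot be read: the limit of > 2 h in this assay, at which 1 of the 4 values shown sits.

Going by these compounds, whether ethyl or isopropyl at this carbon would keep compound 4's standing remains open. So does whether the same change would act alike on the core of compound 2.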